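This account rests on a few compounds, and the source may have more. Where it says the series, first, only, none or still open, it means among the compounds named here.

Working notes on the series in a functional assay on HCT-15 cells (Homo sapiens) for cytotoxicity, in the presence of a further agent that is not named here; on this read-out lower numbers stand for stronger inhibition and higher numbers for weaker inhibition. Compound 1 `Clc1ccc(-c2cc(-c3ccsc3)nc(-c3ccco3)c2)o1` reports only a limit of the assay, > 50000 nM. Compound 2 `Clc1ccc(-c2cc(-c3cccnc3)nc(-c3ccsc3)c2)o1` reports only the same limit, > 50000 nM. For the measured compounds named here, compound 3 `Cc1ccc(-c2cc(-c3ccc(Cl)o3)cc(-c3ccsc3)n2)cc1` gives 7410 nM, the only true number so far. The other two results are limits of the assay, so the standing of compound 3 rests on a single value.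

The next compound, compound 4 `Clc1cccc(-c2cc(-c3ccc(Cl)o3)cc(-c3ccsc3)n2)c1`, carries 3-chlorophenyl in place of 4-methylphenyl on an aromatic carbon.

Going by the values given here, two measured steps concern the same place: an at least 6.7-fold lower number from compound 1 to compound 3 (0.82 log units; beyond the scatter), with 4-methylphenyl in place of furan-2-yl, and an at least 6.7-fold lower number from compound 2 to compound 3 (0.82 log units; beyond the scatter), with 4-methylphenyl in place of pyridin-3-yl. Both start from a limit, so they give only a minimum size, and neither swaps one carbon-only ring for another. Compound 4 keeps a carbon-only six-membered aromatic ring there, as compound 3 does at 7410 nM, so no step beyond the scatter is expected in this assay.

The expected step is a 1.2-fold lower number from compound 3 to compound 4 (0.09 log units; within the scatter). For compound 4 the estimated value is 6000 nM, with an expected range of 2000 nM to 20000 nM.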

Compound 4, half-maximal inhibitory concentration: 13700 nM
For compound 4 the middle estimate is 2.3-fold (0.36 log units) below the measured one, within the range that was stated.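

In this assay, for the compounds shown here, a 1.8-fold higher number from compound 3 to compound 4 (0.27 log units; within the scatter), the first step between two true numbers, and the 3-chlorophenyl and 4-methylphenyl groups are not told apart at this place next to the ring nitrogen. The 3-chlorophenyl group also stands clear of both heteroaromatic rings, with an at least 3.6-fold lower number from compound 2 to compound 4 (0.56 log units; beyond the scatter) and an at least 3.6-fold lower number from compound 1 to compound 4 (0.56 log units; beyond the scatter), so compounds 3 and 4 both show a carbon-only six-membered aromatic ring giving a lower number than pyridin-3-yl or furan-2-yl. Both of these steps are minimum sizes only, because each starts from a limit of the assay: the limit of > 50000 nM in this assay, at which 2 of the 4 values shown sit.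

The 3-chlorophenyl and 4-methylphenyl groups differ in both the substituent and its place on the ring, and the compounds shown do not separate the two. Going by these compounds, how a phenyl ring carrying an amine or a carboxylic acid would read at this place remains open.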